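Replacing Neopentyl with 2-Methoxyphenyl on a Shared Core

This account rests on a few compounds, and the source may have more. Where it says the series, first, only, none or still open, it means among the compounds named here.

Measured so far:
compound 1 `Cc1cccc(Cc2cnc(CCc3ccc(-c4ccccc4C(=O)O)cc3)[nH]2)c1` — 75 nM
compound 2 `CC(C)(C)CCc1cnc(CCc2ccc(-c3ccccc3C(=O)O)cc2)[nH]1` — 6.2 nM

Of the compounds shown here, two have been measured in an in vitro functional assay on cells for agonist activity at Bombesin receptor subtype-3 (Mus musculus), read by luminescence and calcium flux; a higher number here means that more compound is needed for the effect, a lower number that less compound is needed. For the measured compounds named here, compound 2 holds the lowest of the two numbers; its only neighbor is compound 1, and the two are separated by the step of a 12-fold lower number from compound 1 to compound 2 (1.08 log units; beyond the scatter), a large change that came from neopentyl in place of 3-methylphenyl on a saturated chain carbon bound to an aromatic carbon.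

Compound 3 `COc1ccccc1Cc1cnc(CCc2ccc(-c3ccccc3C(=O)O)cc2)[nH]1` has not yet been measured. Compared with compound 2 it differs in one place: 2-methoxyphenyl in place of neopentyl on a saturated chain carbon bound to an aromatic carbon. Going by the values given here, the only measured step that bears on this change is the one from compound 1 to compound 2, which was large and beyond the scatter. Compound 3 brings a six-membered aromatic ring back to the position where compound 2 carries neopentyl, so the expectation is a step in the opposite direction and of comparable size, estimated as an 8.1-fold higher number from compound 2 to compound 3 (0.91 log units; beyond the scatter). On that basis compound 3 is expected to give about 50 nM, with a range of 15 nM to 200 nM.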

Compound 3, half-maximal effective concentration: 163 nM
For compound 3 the middle estimate is 3.3-fold (0.51 log units) below the measured one; low and high end bracket the measured number.
By their numbers in this assay, from the lowest: compound 2; then compound 1; then compound 3.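

In this assay, compound 3 shows that the low number of compound 2 is not matched by either six-membered aromatic group shown at this saturated chain carbon bound to an aromatic carbon: a 26-fold higher number from compound 2 to compound 3 (1.42 log units; beyond the scatter) is a large step, in the opposite direction to the earlier one. It also shows that the two aromatic groups are not interchangeable, since 2-methoxyphenyl in place of 3-methylphenyl gives a 2.2-fold higher number from compound 1 to compound 3 (0.34 log units; beyond the scatter), a modest change but one beyond the usual scatter. Nothing available accounts for the size of either step.

With neopentyl as the only saturated group among these compounds, it remains open whether the low number belongs to that group alone or extends to others, such as cyclohexyl or a longer chain. The two aromatic groups also differ in both the group they carry and its place on the ring, so the separate contributions of methoxy and methyl cannot be told apart without a comparison such as plain phenyl.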